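Removing the Ethyl from the Ester of Compound 2

The compounds below may be only part of what the source reports. "The series", "measured", "known", "first", "only" and "open" are said of these compounds alone.

Three measured compounds share one core, shown in compound 1 `C=C(CC)C(=O)c1ccc(OCC(=O)Nc2ccc(C(=O)OC)cc2)c(Cl)c1Cl`, and differ only in the substituent on the aromatic ring that carries the amide. In a functional assay on CLL cells (Homo sapiens) for cytotoxicity, read by MTT assay, with a stated time of 48 h (on this read-out higher numbers stand for an effect only at larger amounts of compound and lower numbers for an effect already at smaller amounts), compound 1 gives 4100 nM. Compound 2 `C=C(CC)C(=O)c1ccc(OCC(=O)Nc2ccc(/C=C/C(=O)OCC)cc2)c(Cl)c1Cl` bears 2-(ethoxycarbonyl)ethenyl in place of methoxycarbonyl on an aromatic carbon, and in this assay compound 2 gives 1700 nM, the lowest of the three numbers; the step of a 2.4-fold lower number from compound 1 to compound 2 (0.38 log units; beyond the scatter) is modest but beyond the scatter. Compound 3 `C=C(CC)C(=O)c1ccc(OCC(=O)Nc2ccc3c(c2)C(=O)NC3=O)c(Cl)c1Cl` gives 2500 nM in this assay, a number within the scatter of compound 2.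

Compound 4 `C=C(CC)C(=O)c1ccc(OCC(=O)Nc2ccc(/C=C/C(=O)O)cc2)c(Cl)c1Cl` has not yet been measured. It differs from compound 2 by hydrogen in place of ethyl on an oxygen next to a carbonyl group. For the measured compounds named here, no measured pair shows this ester-to-acid change; the only step touching this region, from compound 1 to compound 2, exchanged the whole ester-bearing group rather than the ethyl alone, so it offers no direct guide. Lacking a comparable step, the author expects the number for compound 4 to rise in this assay by a 2.4-fold higher number from compound 2 to compound 4 (0.37 log units; beyond the scatter), with wide uncertainty. Compound 4 is accordingly estimated at 4000 nM, within a range from 1500 nM to 12000 nM.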

Compound 4, half-maximal effective concentration: 3000 nM
Compound 4: middle estimate off by 1.3-fold (0.12 log units), on the high side; measured number inside the range.
By their numbers in this assay, from the lowest: compounds 2, 3, 4 and 1 (each within the scatter of the next, the first and the last beyond it).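

In this assay, hydrogen in place of ethyl on an oxygen next to a carbonyl group gives a 1.8-fold higher number from compound 2 to compound 4 (0.25 log units; within the scatter), so this first direct view of the ester-to-acid change at this position puts compound 2 and compound 4 within the scatter of each other. 2-carboxyethenyl in place of methoxycarbonyl on an aromatic carbon gives a 1.4-fold lower number from compound 1 to compound 4 (0.14 log units; within the scatter), also within the scatter, while 2-(ethoxycarbonyl)ethenyl in the same place gives a 2.4-fold lower number from compound 1 to compound 2 (0.38 log units; beyond the scatter), so compound 4 stands apart from neither compound 1 nor compound 2, and the step between those two remains the only one of these three beyond the scatter. Nothing available explains these numbers or says what the ethyl group contributes to them.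

The compounds shown leave open whether a longer chain such as butyl on this oxygen, or a primary amide in place of the carboxy group, would separate from compound 2 by more than the scatter. They also leave open how a carboxylic acid placed directly on the aromatic carbon, without the ethenyl link, would compare with compound 4 and with compound 1.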